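The compounds below may be only part of what the source reports. "The series", "measured", "known", "first", "only" and "open" are said of these compounds alone.

Series notes. Among the measured compounds shown here, compound 2 `CC(C)Cc1nn(-c2nccs2)cc1C(=O)Nc1ccc(F)cc1` in a toxicity assay on HepG2 2.2.15 cells (Homo sapiens) for cytotoxicity, read by CCK-8 assay, with a stated time of 8 days (a higher number here means that more compound is tolerated, a lower number that less compound is tolerated), gives 83700 nM, the only value in the set reported as a plain number. Compound 1 `CCOC(=O)c1cn(-c2ccccc2F)nc1CC(C)C` in this assay sits at the limit > 100000 nM. Compound 3 `CC(C)Cc1nn(-c2nccs2)cc1C(=O)NCc1ccccc1F` in this assay likewise sits at the limit > 100000 nM. For the measured compounds named here, the single measured step is an at least 1.1-fold higher number from compound 2 to compound 3 (0.07 log units; that floor lies within the scatter), with 2-fluorobenzyl in place of 4-fluorophenyl on an amide-type nitrogen. Compound 4 `CCOC(=O)c1cn(-c2nccs2)nc1CC(C)C` differs from compound 2 by ethoxy in place of (4-fluorophenyl)amino on a carbonyl carbon. Going by the values given here, no measured step covers an ester in place of the amide; the one measured step and the limit of > 100000 nM in this assay, at which 2 of the 3 values shown sit, leave little room for a shift beyond the scatter in this assay. For compound 4 a step of a 1.8-fold higher number from compound 2 to compound 4 (0.25 log units; within the scatter) is expected, most likely ending at the limit. Compound 4 is estimated at 150000 nM in this assay, within 70000 nM to 400000 nM.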

Compound 4, half-maximal cytotoxic concentration: > 100000 nM
Compound 4: no number, only a limit (the forecaster's own chance of this, stated with the estimate: 70%); the middle value lies beyond the limit too.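

Compound 4 in this assay gives > 100000 nM, which is a limit and not a number. Going by these compounds, on the carbonyl carbon, ethoxy in place of (4-fluorophenyl)amino gives an at least 1.1-fold higher number from compound 2 to compound 4 (0.07 log units; that floor lies within the scatter), so an ester here, without the aromatic ring and the amide hydrogen, shows no drop in tolerated concentration, though the full size of the step stays unknown. The step between compound 1 and compound 4 cannot be read, and the series offers little resolution: the limit of > 100000 nM in this assay, at which 3 of the 4 values shown sit.

On these data alone, a carboxylic acid or a dimethylamino group on the carbonyl carbon remains open. So does a longer chain in place of ethoxy.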